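The compounds below may be only part of what the source reports. "The series", "measured", "known", "first", "only" and "open" are said of these compounds alone.

Of the compounds shown here, two have been tested in a functional assay on CHO cells for antagonist activity at gastric inhibitory polypeptide receptor (Homo sapiens), read by cAMP accumulation; on this read-out lower numbers stand for stronger inhibition and higher numbers for weaker inhibition. Compound 1, `CC(C)(C)[C@H]1CC[C@H](c2cc(-c3ccc(OC(F)(F)F)cc3)nn2Cc2ccc(C(=O)Nc3nn[nH]n3)cc2)CC1`, which carries a 2H-tetrazol-5-yl group bound to an amide-type nitrogen, gives 5700 nM in this assay. Compound 2, `O=C(NC[C@@H](O)C(=O)O)c1ccc(Cn2nc(-c3cc(Cl)cc(Cl)c3)cc2-c2ccc(OC(F)(F)F)cc2)cc1`, reaches only the limit of the measurement, recorded as > 25000 nM, so no number is known for it. On this read-out compound 2 therefore stands at the weak end of what was seen; it is the compound that sits at the limit of > 25000 nM in this assay, at which 1 of the 2 values shown sits.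

Compound 3, `O=C(NCc1nn[nH]n1)c1ccc(Cn2nc(-c3cc(Cl)cc(Cl)c3)cc2-c2ccc(OC(F)(F)F)cc2)cc1`, shares the core of compound 2 and differs from it in a single place: 2H-tetrazol-5-yl in place of carboxy(hydroxy)methyl on a saturated chain carbon bound to an amide-type nitrogen. Whether this change moves the read-out cannot be taken from a measured step, since compound 2 gives only a limit. Within the data shown here, the one guide is compound 1, whose 2H-tetrazol-5-yl group goes with 5700 nM, so a move toward stronger inhibition is expected, with the expected step being an at least 3.1-fold lower number from compound 2 to compound 3 (0.49 log units; beyond the scatter). For compound 3 the estimated value is 8000 nM, expected to fall between 2000 nM and 25000 nM in this assay.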

Compound 3, half-maximal inhibitory concentration: > 10000 nM
Compound 3: only a limit was reported; the forecaster's own chance of this, stated with the estimate: 35%; middle value at least 1.2-fold (0.09 log units) away from the limit.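

Among these compounds, compound 2 and compound 3 are both reported only as limits, so no step between them can be read. The compounds shown leave open whether 2H-tetrazol-5-yl in place of carboxy(hydroxy)methyl on a saturated chain carbon bound to an amide-type nitrogen moves the read-out at all, and in which direction.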